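The source may hold more compounds than are shown below. What is called first, only, known or untested is meant among the compounds shown, and "the series" means these compounds.

Measured compounds:
- compound 1, `CCc1ccccc1N(Cc1nnc(Cc2ccc(Cl)cc2)o1)S(=O)(=O)c1ccc(C)cc1`, 398 nM in an assay on CHO cells for displacement of a labelled ligand from prostaglandin E2 receptor EP1 subtype (Homo sapiens); on this read-out higher numbers stand for weaker inhibition and lower numbers for stronger inhibition
- compound 2, `Cc1ccc(S(=O)(=O)N(Cc2nnc(Cc3c(Cl)cccc3Cl)o2)c2cccc(Cl)c2C)cc1`, 63.1 nM in this assay

Of these two numbers compound 1 has the higher one, and the gap to compound 2 lies beyond the usual scatter, so compound 2 is the stronger of the pair on this assay. For the measured compounds named here, no single-change step between compound 1 and compound 2 is available, so their values are taken only as they stand.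

Compound 3, `CCc1ccccc1N(Cc1nnc(CNc2ccc(OC)cc2)o1)S(=O)(=O)c1ccc(C)cc1`, is the not yet measured compound. It differs from compound 1 by (4-methoxyphenyl)amino in place of 4-chlorophenyl on a saturated chain carbon bound to an aromatic carbon. Going by the values given here, since no measured pair shows this particular change, there is no directly comparable step on this assay to lean on. The step from compound 1 to compound 3 is expected to be a 1.5-fold higher number from compound 1 to compound 3 (0.18 log units; within the scatter), a modest movement whose direction is uncertain. For compound 3 the expected value on this assay is 600 nM, with a range from 200 nM to 2000 nM.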

Compound 3, half-maximal inhibitory concentration: 501 nM
Compound 3: the middle estimate sits 1.2-fold (0.08 log units) above what was measured; measured number inside the range.
By their numbers in this assay, from the lowest: compound 2; then compounds 1 and 3 (each within the scatter of the next).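

In this assay, the change gives a 1.3-fold higher number from compound 1 to compound 3 (0.10 log units; within the scatter), so this position on a saturated chain carbon bound to an aromatic carbon accepts (4-methoxyphenyl)amino in place of 4-chlorophenyl with no difference that can be read. For the compounds shown here, this is the first single-place comparison, and it holds even though the entering group brings a hydrogen-bond donor and hydrogen-bond acceptors that the leaving group does not have. Nothing measured on these compounds accounts for this result.

The exchange alters the amino link and the ring substituent at once, so the compounds shown leave open what each contributes on its own. A plain phenylamino or a 4-methoxyphenyl without the amino link would separate the two, and a carboxylic acid at this place remains an open question as well.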